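Hydroxy to methoxy in compound 1

This account rests on a few compounds, and the source may have more. Where it says the series, first, only, none or still open, it means among the compounds named here.

Measured so far in a functional assay on DU-145 cells (Homo sapiens) for antiproliferative activity, read by sulforhodamine B assay, with a stated time of 48 h; on this read-out higher numbers stand for weaker inhibition and lower numbers for stronger inhibition
- compound 1 `O=C(NCCCNc1cc(-c2cn(-c3ccccc3)nc2-c2cccc(O)c2)ccn1)Nc1ccc(F)cc1` gives 4220 nM
- compound 2 `O=C(NCCCNc1cc(-c2cn(-c3ccccc3)nc2-c2cccc(O)c2)ccn1)Nc1cccc(C(F)(F)F)c1` gives 4800 nM

Among the compounds with values here, compound 1 at 4220 nM stands level, within the scatter, with compound 2, its only measured neighbour. Within the data shown here, the single measured step is a 1.1-fold higher number from compound 1 to compound 2 (0.06 log units; within the scatter), and it concerns the aryl group on an amide-type nitrogen.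

Compound 3 `COc1cccc(-c2nn(-c3ccccc3)cc2-c2ccnc(NCCCNC(=O)Nc3ccc(F)cc3)c2)c1` keeps that 4-fluorophenyl and the shared core of compound 1 and changes another place: methyl in place of hydrogen on an oxygen on an aromatic ring. This is the change from 3-hydroxyphenyl to 3-methoxyphenyl.

Among the measured compounds shown here, no measured step touches this oxygen, so the data give no direct reading of the change. The step at the amide-type nitrogen stayed within the scatter, but it cannot be carried over to a different place. Two compounds offer no basis for a direction, so no shift beyond the scatter is expected in this assay, and the anchor for the expectation remains compound 1 at 4220 nM. The expected step is a 1.1-fold higher number from compound 1 to compound 3 (0.03 log units; within the scatter). For compound 3 the estimated value is 4500 nM, with an expected range from 1600 nM to 12000 nM.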

Compound 3, half-maximal inhibitory concentration: 14000 nM
For compound 3 the middle estimate is 3.1-fold (0.49 log units) below the measured one; measured number outside the range, above it.
By their numbers in this assay, from the lowest: compounds 1 and 2 (each within the scatter of the next); then compound 3.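

In this assay the oxygen on the aromatic ring proves to be a place that responds: methyl in place of hydrogen on it gives a 3.3-fold higher number from compound 1 to compound 3 (0.52 log units; beyond the scatter) on the core of compound 1, with the 4-fluorophenyl kept. Within the data shown here, the only earlier step, at the amide-type nitrogen, gave a 1.1-fold higher number from compound 1 to compound 2 (0.06 log units; within the scatter) and so showed no response at that place, which makes this oxygen the first position where a change moves the number beyond the scatter, towards weaker inhibition, though the shift is modest and rests on this single pair. No available measurement bears on why hydroxy to methoxy weakens inhibition here.

Going by these compounds, it remains open whether the same step would appear with the 3-(trifluoromethyl)phenyl of compound 2 in place of the 4-fluorophenyl. Also open, on these data alone, is whether the weakening follows from losing the hydrogen or from adding the methyl, a question that an amine or a longer ether such as ethoxy at this place on the 3-substituted phenyl would help to separate.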